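The source may hold more compounds than are shown below. What is called first, only, known or untested is meant among the compounds shown, and "the series" means these compounds.

Three nucleoside analogues built on one shared core have been tested in a functional assay on K562 cells (Homo sapiens), read by MTT assay, with a stated time of 72 h; on this read-out higher numbers stand for weaker inhibition and lower numbers for stronger inhibition. Compound 1 `COc1ncnc2c1c(-c1ccoc1)cn2[C@@H]1O[C@H](CO)[C@@H](O)[C@H]1O` gives 2820 nM in this assay. Compound 2 `CSc1ncnc2c1c(-c1ccoc1)cn2[C@@H]1O[C@H](CO)[C@@H](O)[C@H]1O` gives 3250 nM in this assay. Compound 3 `C#Cc1cn([C@@H]2O[C@H](CO)[C@@H](O)[C@H]2O)c2ncnc(OC)c12` gives 380 nM in this assay.

Two single changes link these numbers. Between compound 1 and compound 2 the change is methylsulfanyl in place of methoxy on an aromatic carbon, and it made a 1.2-fold higher number from compound 1 to compound 2 (0.06 log units; within the scatter). Between compound 1 and compound 3 the change is ethynyl in place of furan-3-yl on an aromatic carbon, and it made a 7.4-fold lower number from compound 1 to compound 3 (0.87 log units; beyond the scatter). The first change is thus too small to separate from repeat scatter, while the second is a clear move toward stronger inhibition.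

Compound 4 `C#Cc1cn([C@@H]2O[C@H](CO)[C@@H](O)[C@H]2O)c2ncnc(SC)c12` has not yet been measured. It differs from compound 3 by methylsulfanyl in place of methoxy on an aromatic carbon, which is the same change already seen between compound 1 and compound 2, made at the same place. The two cores on which the change is made differ as described by ethynyl in place of furan-3-yl on an aromatic carbon.

The expectation for compound 4 rests on the step already made by this change, because a 1.2-fold higher number from compound 1 to compound 2 (0.06 log units; within the scatter) showed that methylsulfanyl in place of methoxy on an aromatic carbon left the number essentially where it stood. For compound 3 to compound 4 the expected step is a 1.2-fold higher number from compound 3 to compound 4 (0.06 log units; within the scatter). Compound 4 is therefore estimated at 440 nM in this assay, with the likely range running from 200 nM to 950 nM.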

Compound 4, half-maximal inhibitory concentration: 70 nM
Beside the measured number, compound 4's estimate is 6.3-fold (0.80 log units) above it, and the stated range ends above it.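

In this assay, methylsulfanyl in place of methoxy on an aromatic carbon gave a 5.4-fold lower number from compound 3 to compound 4 (0.73 log units; beyond the scatter), so on the core carrying ethynyl this change did not behave as it had on the core carrying furan-3-yl: the same change on two cores in this assay, a 1.2-fold higher number (0.06 log units; within the scatter) from compound 1 to compound 2 and a 5.4-fold lower number (0.73 log units; beyond the scatter) from compound 3 to compound 4, 6.3-fold (0.80 log units) apart, beyond the scatter of two such steps Seen from the other side, ethynyl in place of furan-3-yl gave a 46-fold lower number from compound 2 to compound 4 (1.67 log units; beyond the scatter), and this step also differs from the earlier one for the same change: the same change on two cores in this assay, a 7.4-fold lower number (0.87 log units; beyond the scatter) from compound 1 to compound 3 and a 46-fold lower number (1.67 log units; beyond the scatter) from compound 2 to compound 4, 6.3-fold (0.80 log units) apart, beyond the scatter of two such steps These two comparisons use the same four compounds, so they make one finding: here the effect of each change depends on the group present at the other site, and a step measured on one core could not simply be carried to the other, although this does not show why the steps differ or how general this behaviour is.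

The compounds shown leave open whether methylsulfanyl would bring a similar drop with a group other than ethynyl or furan-3-yl on the core, such as a phenyl ring or a longer alkyne chain. They also leave open how an amine or a plain methyl group would compare with methoxy and methylsulfanyl on that aromatic carbon.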